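Series notes: aryl amide to pyrrolidinylethyl amide

The source may report more compounds than this note shows. Statements on the series, on what has been measured and on what is new or still open speak of the compounds shown alone.

Compound 1 `O=C(CCC(=O)OCCCCCCSc1ccc([N+](=O)[O-])c2nonc12)Nc1ccccc1Cl` is the weakest inhibitor of the three measured compounds: in an assay on isolated protein for inhibition of glutathione S-transferase P (Homo sapiens), with a stated time of 10 min (a lower number here means a stronger inhibitor, a higher number a weaker inhibitor), compound 1 gives 15500 nM. Compound 2 `O=C(CCC(=O)OCCCCCCSc1ccc([N+](=O)[O-])c2nonc12)Nc1ccc(C(F)(F)F)cc1` gives 5050 nM in this assay, and compound 3 `COc1ccc(NC(=O)CCC(=O)OCCCCCCSc2ccc([N+](=O)[O-])c3nonc23)cc1OC` gives 6470 nM. Each aryl swap on the amide-type nitrogen brings a modest gain: a 3.1-fold lower number from compound 1 to compound 2 (0.49 log units; beyond the scatter) and a 2.4-fold lower number from compound 1 to compound 3 (0.38 log units; beyond the scatter). Between the two substituted aryl groups the difference is small, a 1.3-fold higher number from compound 2 to compound 3 (0.11 log units; within the scatter).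

Compound 4 `O=C(CCC(=O)OCCCCCCSc1ccc([N+](=O)[O-])c2nonc12)NCCN1CCCC1` takes a different direction. 2-(pyrrolidin-1-yl)ethyl in place of 2-chlorophenyl on an amide-type nitrogen Neither measured step bears directly on this change: both replace one six-membered aromatic ring with another, whereas here the aromatic ring leaves and a five-membered non-aromatic ring with one hetero atom enters on the amide-type nitrogen. Among the measured compounds shown here, the gains seen for compounds 2 and 3 therefore give no footing for compound 4, and no compound without an aryl group on that nitrogen has been measured. For the measured compounds named here, with no comparable step, no change beyond the scatter is expected in either direction, though the uncertainty is wide. The step from compound 1 is estimated as a 1.3-fold higher number from compound 1 to compound 4 (0.11 log units; within the scatter). For compound 4 the expected value in this assay is 20000 nM, with a range from 6000 nM to 60000 nM.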

Compound 4, half-maximal inhibitory concentration: 460 nM
Compound 4: the middle estimate sits 43-fold (1.64 log units) above what was measured, outside the stated range (below it).
By their numbers in this assay, from the lowest: compound 4; then compounds 2 and 3 (each within the scatter of the next); then compound 1.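

Taking the aromatic ring off the amide-type nitrogen does far more in this assay than exchanging one aryl group for another, with 2-(pyrrolidin-1-yl)ethyl giving large steps from all three aryl amides: (a 34-fold lower number from compound 1 to compound 4 (1.53 log units; beyond the scatter)), (a 14-fold lower number from compound 3 to compound 4 (1.15 log units; beyond the scatter)) and (an 11-fold lower number from compound 2 to compound 4 (1.04 log units; beyond the scatter)). This position therefore has a much wider span than the aryl amides alone showed, and it does not need an aryl group for inhibition, since the best number in the set comes from the compound without one. Between compound 1 and compound 4 the heavy-atom count stays the same while a six-membered aromatic ring of carbon is exchanged for a five-membered non-aromatic ring with a hetero atom and a hydrogen-bond acceptor enters, but nothing at hand explains the size of this step.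

The compounds shown do not separate the contributions of the pyrrolidine ring, its nitrogen and the ethyl chain, so a 2-(dimethylamino)ethyl group, a 2-(piperidin-1-yl)ethyl group, a 2-morpholinoethyl group or a plain alkyl chain on the amide nitrogen would each bear on this. A longer chain, such as 3-(pyrrolidin-1-yl)propyl, would show whether the distance from the amide to the ring matters.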